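The source may report more compounds than this note shows. Statements on the series, on what has been measured and on what is new or still open speak of the compounds shown alone.

Measured so far:

Compound 1 `Cc1ccc(Nc2cncc(N3CC4CC(C3)N4)c2)cc1`, in an assay on cell membranes for displacement of a labelled ligand from Neuronal acetylcholine receptor; alpha4/beta2 (Rattus norvegicus) (on this read-out higher numbers stand for weaker inhibition and lower numbers for stronger inhibition), compound 1 gives 0.148 nM.
Compound 2 `Clc1ccc(Nc2cncc(N3CC4CC(C3)N4)c2)cc1`, in this assay compound 2 gives 0.118 nM.
Compound 3 `Clc1ccc(Nc2ccc(N3CC4CC(C3)N4)nn2)cc1`, in this assay compound 3 gives 90.4 nM.

Compounds 1 and 2 share one core and differ only by methyl in place of chloro on an aromatic carbon; this change gave a 1.3-fold higher number from compound 2 to compound 1 (0.10 log units; within the scatter). Compound 3 carries a different core; how the two cores differ is not broken down here, and the values of compound 2 and compound 3 simply show that compound 3 sits far higher in this assay.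

Compound 4 `Cc1ccc(Nc2ccc(N3CC4CC(C3)N4)nn2)cc1` has not yet been measured. It differs from compound 3 by methyl in place of chloro on an aromatic carbon, the same change that turned compound 2 into compound 1, made at the same place. On the core of compound 4 the effect is expected to be similar, so a step of a 1.2-fold higher number from compound 3 to compound 4 (0.09 log units; within the scatter) is estimated, resting on the step of a 1.3-fold higher number from compound 2 to compound 1 (0.10 log units; within the scatter) seen on the other core. Compound 4 is therefore expected to give about 110 nM in this assay, with a plausible range from 40 nM to 300 nM.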

Compound 4, inhibition constant: 44.3 nM
Compound 4: middle estimate off by 2.5-fold (0.39 log units), on the high side; low and high end bracket the measured number.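

In this assay, putting methyl in place of chloro on the core of compound 3 gave a 2.0-fold lower number from compound 3 to compound 4 (0.31 log units; beyond the scatter) as a modest change. Set beside the same change on the other core, the two steps do not differ by more than repeated measurements would allow: the same change on two cores in this assay, a 1.3-fold higher number (0.10 log units; within the scatter) from compound 2 to compound 1 and a 2.0-fold lower number (0.31 log units; beyond the scatter) from compound 3 to compound 4, 2.6-fold (0.41 log units) apart, within the scatter of two such steps. So the change from 4-chlorophenyl to 4-methylphenyl carried over between these two cores without a clear difference, but two pairs do not show that the steps are identical, why they behave this way, or what would happen on a third core.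

From the compounds shown here alone, only chloro and methyl appear at this place, so it remains open how an amine, a carboxylic acid or a longer chain there would fare. Going by these compounds, whether any such group would carry over between the two cores is also open.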